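Moving the methylsulfanyl group around the ring

The compounds below may be only part of what the source reports. "The series", "measured", "known", "first", "only" and "open" are said of these compounds alone.

In a functional assay on CRL2813 cells (Homo sapiens) for cytotoxicity, read by sulforhodamine B assay, with a stated time of 5 days (on this read-out higher numbers stand for weaker inhibition and lower numbers for stronger inhibition), compound 3 `CSc1cccc(NC(=O)N[C@H]2CC[C@H](Oc3ccc(F)cc3)CC2)c1` gives 11100 nM, the lowest of the two numbers available. Compound 2 `O=C(Nc1ccc(F)cc1)N[C@H]1CC[C@H](Oc2ccc(F)cc2)CC1` gives 20000 nM, and a 1.8-fold lower number from compound 2 to compound 3 (0.26 log units; within the scatter). Compound 1 `COc1ccccc1NC(=O)N[C@H]1CC[C@H](Oc2ccc(F)cc2)CC1` sits at the limit of the assay, giving > 20000 nM. Compound 4 `CSc1ccc(NC(=O)N[C@H]2CC[C@H](Oc3ccc(F)cc3)CC2)cc1` differs from compound 3 by 4-(methylsulfanyl)phenyl in place of 3-(methylsulfanyl)phenyl on an amide-type nitrogen. Going by the values given here, no measured step moves a methylsulfanyl group from one position to another; the steps that bear on it exchange the whole aryl group, and an at least 1.8-fold lower number from compound 1 to compound 3 (0.25 log units; that floor lies within the scatter) while a number no higher from compound 1 to compound 2 (the limit leaves the size open). In this assay, therefore, no shift beyond the scatter is expected, with a 1.0-fold lower number from compound 3 to compound 4 (0.00 log units; within the scatter). Compound 4 is accordingly estimated at 11000 nM, between 5000 nM and 25000 nM.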

Compound 4, half-maximal inhibitory concentration: > 20000 nM
Compound 4 was reported as a limit; the forecaster's own chance of this, stated with the estimate: 25%; at least 1.8-fold (0.25 log units) between middle value and limit.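

In this assay, 4-(methylsulfanyl)phenyl in place of 3-(methylsulfanyl)phenyl on an amide-type nitrogen gives an at least 1.8-fold higher number from compound 3 to compound 4 (0.25 log units; that floor lies within the scatter), so no effect of moving the methylsulfanyl group is established. Compound 4 is reported only as a limit. Methylsulfanyl in place of fluoro on an aromatic carbon gives a number no lower from compound 2 to compound 4 (the limit leaves the size open). The step to compound 4 from compound 1 cannot be read: the limit of > 20000 nM in this assay, at which 2 of the 4 values shown sit.

On these data alone, how far compound 4 truly lies from compound 3 stays open. Also open, as far as these compounds go, is whether an amine or a carboxylic acid on the aromatic ring in place of methylsulfanyl would shift the number beyond the scatter.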